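Trifluoromethoxy in Place of Fluoro on a Shared Core

The source may report more compounds than this note shows. Statements on the series, on what has been measured and on what is new or still open speak of the compounds shown alone.

Compound 1, `CCCC(=O)Nc1cccc(NC(=O)c2ccccc2F)c1`, gives 970 nM in an assay on a cell-free system (plasma) for inhibition of proteinase-activated receptor 1 (Homo sapiens), read by flow cytometry, with a stated time of 20 min; a lower number here means a stronger inhibitor, a higher number a weaker inhibitor.
Compound 2, `CCCC(=O)Nc1cccc(NC(=O)c2ccccc2Cl)c1`, gives 1100 nM in this assay.
Compound 3, `CCCC(=O)Nc1cccc(NC(=O)c2ccccc2C)c1`, gives 770 nM in this assay.

The three measured compounds share one core and differ only in the group on an aromatic carbon. Compound 1 stands second highest of the three numbers; its nearest neighbour is compound 2, with a 1.1-fold higher number from compound 1 to compound 2 (0.05 log units; within the scatter), and its furthest is compound 3, with a 1.3-fold lower number from compound 1 to compound 3 (0.10 log units; within the scatter). Between the other two, a 1.4-fold lower number from compound 2 to compound 3 (0.15 log units; within the scatter). None of these steps goes beyond the scatter, so the three compounds cannot be told apart in this assay.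

Compound 4, `CCCC(=O)Nc1cccc(NC(=O)c2ccccc2OC(F)(F)F)c1`, has not yet been measured. It differs from compound 1 in one place: trifluoromethoxy in place of fluoro on an aromatic carbon. For the measured compounds named here, the steps that bear on this are the exchanges of fluoro for chloro and for methyl, all of which stayed within the scatter; none of them introduces a group that resembles trifluoromethoxy, so the guidance is indirect. The expectation for compound 4 in this assay is therefore a step of a 1.0-fold higher number from compound 1 to compound 4 (0.01 log units; within the scatter), with no direction beyond the scatter favoured. The estimated value for compound 4 is 1000 nM, within a range from 400 nM to 3000 nM.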

Compound 4, half-maximal inhibitory concentration: 710 nM
Compound 4: middle estimate off by 1.4-fold (0.15 log units), on the high side; low and high end bracket the measured number.
By their numbers in this assay, from the lowest: compounds 4, 3, 1 and 2 (each within the scatter of the next).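

Trifluoromethoxy, a group of 5 heavy atoms with 1 hydrogen-bond acceptor, can take the place of fluoro on this aromatic carbon, ortho to a large group, and the reading in this assay stays within the scatter (a 1.4-fold lower number from compound 1 to compound 4 (0.14 log units; within the scatter)). The same is true when it replaces the other two groups (a 1.1-fold lower number from compound 3 to compound 4 (0.04 log units; within the scatter); a 1.5-fold lower number from compound 2 to compound 4 (0.19 log units; within the scatter)), so the earlier finding that this position does not separate the compounds now extends to a much larger group, and all four compounds remain indistinguishable. No measurement is available that could explain why these groups give such similar readings.

The compounds shown do not reveal whether any group at this position would carry the number beyond the scatter, in either direction; an amine, a carboxylic acid or a plain hydrogen in place of fluoro would each test this. They also leave open whether the rest of the core is just as undemanding, for example whether a longer chain on the other amide would change the reading.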